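From compound 2 to compound 3 at the assay limit

The source may report more compounds than this note shows. Statements on the series, on what has been measured and on what is new or still open speak of the compounds shown alone.

Compound 1 `C=C[C@](C)(CCCC(C)C)CCc1ccc(O)cc1`: > 36600 nM
Compound 2 `C=C[C@@](C)(/C=C/c1ccc(O)cc1)CCC(O)C(C)(C)O`: > 36600 nM

In a functional assay on SEM cells (Homo sapiens) for cytotoxicity, with a stated time of 72 h (a higher number here means that more compound is needed for the effect, a lower number that less compound is needed), compound 2 gives > 36600 nM, which is a limit of the assay and not a number. The whole picture so far is the limit of > 36600 nM in this assay, at which 2 of the 2 values shown sit, so neither compound offers a true value to build on.

Compound 3 `C=C[C@@](C)(/C=C/c1ccc(O)cc1)CC/C=C(C)/C=N/N` alters compound 2 in one place: a group of 6 heavy atoms (4 carbon, 2 nitrogen; no ring) in place of a group of 6 heavy atoms (4 carbon, 2 oxygen; no ring), on a saturated chain carbon, three bonds along the chain from two double-bonded chain carbons. The 1,2-dihydroxy-2-methylpropyl group leaves a saturated chain carbon, and a group with no ring enters there.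

Among the measured compounds shown here, no measured pair differs in just one place, so no measured step shows how large such a change might be. A modest move toward a lower number is expected in this assay, though compound 3 may equally stay at the limit. The expected change is an at least 1.4-fold lower number from compound 2 to compound 3 (0.16 log units; that floor lies within the scatter). Compound 3 is estimated at 25000 nM, with an expected range from 8000 nM to 50000 nM.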

Compound 3, half-maximal effective concentration: > 36600 nM
Compound 3: no number, only a limit; the forecaster's own chance of this, stated with the estimate: 55%; at least 1.4-fold (0.16 log units) between middle value and limit.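

In this assay compound 3 gives > 36600 nM, which is a limit of the assay and not a number. Compound 2 also stands at a limit, so the step from compound 2 to compound 3 cannot be read. The compounds shown leave open what change, if any, would give a true value: the limit of > 36600 nM in this assay, at which 3 of the 3 values shown sit.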